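Chain Extension and Growth Inhibition in Four Related Compounds

The compounds below may be only part of what the source reports. "The series", "measured", "known", "first", "only" and "open" are said of these compounds alone.

Compound 1 `CCOc1cc(=O)n(CCCO)c2c1CC(CC=C(C)C)C(C)(C)C2` carries an ethoxy group and a short branched side chain on its saturated ring. In a functional assay on PANC-1 cells (Homo sapiens) for inhibition, read by MTT assay, with a stated time of 24 h, tested at 10 uM (a higher number here means more inhibition at the concentration tested (going by the name of the read-out), a lower number less inhibition), compound 1 gives 66.5%, the highest of the three measured numbers. Compound 2 `CC(C)=CCOc1cc(=O)n(CCCO)c2c1CC(CC=C(C)C)C(C)(C)C2` gives 20.7% in this assay, and the step of a number 45.8 percentage points lower from compound 1 to compound 2 (beyond the scatter) is large. Compound 3 `CC(C)=CCC/C(C)=C/COc1cc(=O)n(CCCO)c2c1CC(CC=C(C)C)C(C)(C)C2` gives 10.6% in this assay; the step of a number 10.1 percentage points lower from compound 2 to compound 3 (beyond the scatter) is modest, and it comes from the change (3-methylbut-2-en-1-yl in place of hydrogen on a saturated chain carbon bound to a double-bonded chain carbon).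

Compound 4 `CCOc1cc(=O)n(CCCO)c2c1CC(C/C=C(\C)CCC=C(C)C)C(C)(C)C2` has not yet been measured. It differs from compound 1 by 3-methylbut-2-en-1-yl in place of hydrogen on a saturated chain carbon bound to a double-bonded chain carbon, which is the same change as that from compound 2 to compound 3, and both place descriptions match word for word. The two starting cores, however, are not the same: compound 1 differs from compound 2 by methyl in place of 2-methylprop-1-en-1-yl on a saturated chain carbon bound to an oxygen on an aromatic ring.

Going by the values given here, for compound 4 a step of a number 11.5 percentage points lower from compound 1 to compound 4 (beyond the scatter) is expected, resting on the single earlier example a number 10.1 percentage points lower from compound 2 to compound 3 (beyond the scatter) seen between compound 2 and compound 3. Among the compounds with values here, compound 4 is therefore estimated at 55% in this assay, with a likely range from 35% to 70%, the width reflecting that only one instance of this change is known and that it was measured on a different core.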

Compound 4, a percentage reported as inhibition, at one concentration (the size of the read-out at that concentration, not a potency): 67.8%
Compound 4: middle estimate off by 12.8 percentage points, on the low side; the measured number falls inside the stated range.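

In this assay, putting 3-methylbut-2-en-1-yl in place of hydrogen on a saturated chain carbon bound to a double-bonded chain carbon gives a step of a number 1.3 percentage points higher from compound 1 to compound 4 (within the scatter), so this assay does not separate the two compounds. Set beside the earlier example, the change cannot be told apart on the two cores: the same change on two cores in this assay, a number 10.1 percentage points lower (beyond the scatter) from compound 2 to compound 3 and a number 1.3 percentage points higher (within the scatter) from compound 1 to compound 4, 11.4 percentage points apart, within the scatter of two such steps. Going by these compounds alone, this does not show that the change has one fixed size on every core, since it rests on only two cores, each read at a single concentration, and says nothing about a third.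

The compounds shown leave open whether a chain ending in an amine or a carboxylic acid, in place of 3-methylbut-2-en-1-yl, would read like compound 4 on the same core. They also leave open what happens when a 3,7-dimethylocta-2,6-dien-1-yl chain stands on both the oxygen and the saturated ring of one compound.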